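This account rests on a few compounds, and the source may have more. Where it says the series, first, only, none or still open, it means among the compounds named here.

Compound 1 `CNC(=O)c1cc(C(=O)NCCO)cn(Cc2ccccc2)c1=O`: >= 140 ug/mL
Compound 2 `CNC(=O)c1cc(C(=O)NC2CC2)cn(Cc2cccc3cc[nH]c23)c1=O`: >= 144 ug/mL
Compound 3 `CNC(=O)c1cc(C(=O)NC2CC2)cn(Cc2cccc([C@@H](C)O)c2)c1=O`: >= 131 ug/mL

In a physicochemical assay for solubility (on this read-out higher numbers stand for higher solubility and lower numbers for lower solubility), compound 1 gives >= 140 ug/mL, a limit of the assay and not a number. Compound 2 likewise gives >= 144 ug/mL, also a limit. Compound 3 gives >= 131 ug/mL, again a limit. Among the measured compounds shown here, all three values therefore sit at limits (the limit of >= 131 ug/mL in this assay, at which 1 of the 3 values shown sits), (the limit of >= 140 ug/mL in this assay, at which 1 of the 3 values shown sits), (the limit of >= 144 ug/mL in this assay, at which 1 of the 3 values shown sits), and the one single-point step, a step that the two limits leave unreadable from compound 2 to compound 3, cannot be read. Compound 4 `CNC(=O)c1cc(C(=O)NCCOC)cn(Cc2ccccc2)c1=O` differs from compound 1 by methyl in place of hydrogen on an oxygen on a saturated carbon. For the measured compounds named here, no measured step bears directly on this change, so no direction can be drawn from the three compounds. The step expected is a number no higher from compound 1 to compound 4 (the limit leaves the size open), most likely again ending at a limit. Compound 4 is expected to give 140 ug/mL, within 60 ug/mL to 300 ug/mL.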

Compound 4, solubility: >= 164 ug/mL
Compound 4 gave a limit, no number; the forecaster's own chance of this, stated with the estimate: 70%; middle value at least 1.1-fold (0.06 log units) from the limit.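

Compound 1 and compound 4 both gave a limit and not a number, so the step between them cannot be read. The compounds shown leave open whether methyl in place of hydrogen on that oxygen shifts the result in this assay at all.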